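A few compounds are considered here, and "the series" means these few. Any claim that something is new, unique, unknown or untested is made for them only; others in the source may bear on it.

Compound 1 `Cc1cc2[nH]nc(N)c2c(N2CCCCC2)n1` stands lowest of the three compounds measured in an assay on isolated protein for inhibition of MAP kinase-activated protein kinase 2 (Homo sapiens), read by mobility shift assay, tested at 30 uM (a higher number here means more inhibition at the concentration tested (going by the name of the read-out), a lower number less inhibition), where compound 1 gives -1%. Its nearest neighbour on that scale is compound 3 `COC(=O)CCc1c(C)[nH]c(=O)c2c(N)nn(C)c12`, which in this assay gives 11%, a gap beyond the scatter. Compound 2 `COc1ccc(-c2cc3c(c(N)nn3C)c(=O)[nH]2)cc1` lies furthest away, giving 51% in this assay. Compound 4 `Cc1cc2c(c(N)nn2C)c(N2CCCCC2)n1` has not yet been measured. It differs from compound 1 in one place (methyl in place of hydrogen on an aromatic nitrogen). For the measured compounds named here, no step between two measured compounds matches this change, so compounds 2 and 3, built differently, show only their own values. Compound 4 is expected to give 5%, within a range of -15% to 30%. The step of a number 6 percentage points higher from compound 1 to compound 4 (within the scatter) expected here is small and may be no bigger than the scatter.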

Compound 4, a percentage reported as inhibition, at one concentration (the size of the read-out at that concentration, not a potency): 7%
Compound 4: the middle estimate sits 2 percentage points below what was measured; low and high end bracket the measured number.
By their numbers in this assay, from the lowest: compounds 1, 4 and 3 (each within the scatter of the next, the first and the last beyond it); then compound 2.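

In this assay, methyl in place of hydrogen on an aromatic nitrogen gives a number 8 percentage points higher from compound 1 to compound 4 (within the scatter). On the core of compound 1, this nitrogen therefore carries a methyl with no step that can be told from the scatter, so the hydrogen there is not shown to matter for this read-out. No measurement at hand bears on this result.

Going by these compounds, whether an ethyl group or a longer chain on this nitrogen would give a step beyond the scatter stays open. So does the effect of an amine or a carboxylic acid at the end of such a chain.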